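Adding a second methoxy to the aryl amide

This account rests on a few compounds, and the source may have more. Where it says the series, first, only, none or still open, it means among the compounds named here.

Compound 2 `COc1ccc(NC(=O)CCC(=O)OCCCCCCSc2ccc([N+](=O)[O-])c3nonc23)cc1` is a close relative of compound 1 `Cc1ccccc1NC(=O)CCC(=O)OCCCCCCSc1ccc([N+](=O)[O-])c2nonc12`. In a functional assay on 143B cells (Homo sapiens) for inhibition, read by MTT assay, with a stated time of 72 h (a higher number here means a weaker inhibitor, a lower number a stronger inhibitor), compound 2 gives 3060 nM, the lower of the two numbers measured, while compound 1 gives 4660 nM; the step of a 1.5-fold lower number from compound 1 to compound 2 (0.18 log units; within the scatter) lies within the scatter. Compound 3 `COc1ccc(NC(=O)CCC(=O)OCCCCCCSc2ccc([N+](=O)[O-])c3nonc23)cc1OC` carries the change (methoxy in place of hydrogen on an aromatic carbon). For the measured compounds named here, no measured step tests this change; the one measured step concerns a different change and was small. The expected step of a 1.0-fold lower number from compound 2 to compound 3 (0.01 log units; within the scatter) is therefore none beyond the scatter. For compound 3 the estimate in this assay is 3000 nM, between 1500 nM and 6500 nM.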

Compound 3, half-maximal inhibitory concentration: 2770 nM
Estimate against measurement, compound 3: 1.1-fold (0.03 log units) above, within the range that was stated.
By their numbers in this assay, from the lowest: compounds 3, 2 and 1 (each within the scatter of the next).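

In this assay, methoxy in place of hydrogen on the aromatic carbon ortho to a methoxy group gives a 1.1-fold lower number from compound 2 to compound 3 (0.04 log units; within the scatter), so this second methoxy shifts the number by no more than repeated measurements would. The wider swap to 3,4-dimethoxyphenyl on the amide nitrogen gives a 1.7-fold lower number from compound 1 to compound 3 (0.23 log units; within the scatter), which also stays inside the scatter. Nothing available explains why these numbers lie so close together.

On these data alone, whether an amine or a carboxylic acid at this ring position would leave the number just as unmoved remains open.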